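This account rests on a few compounds, and the source may have more. Where it says the series, first, only, none or still open, it means among the compounds named here.

Measured compounds:
- compound 1 `COc1ccc(/C=N/NC(=O)Nc2ccc(Oc3ccnc(-c4nncn4CCN(C)C)c3)c(F)c2)c(OC)c1`: 1780 nM
- compound 2 `COc1ccc(/C=N/NC(=O)Nc2ccc(Oc3ccnc(-c4nncn4CCN(C)C)c3)c(F)c2)c(OC)c1OC`: 3970 nM

Of the compounds shown here, two have been measured in a functional assay on HT-29 cells (Homo sapiens) for cytotoxicity, read by MTT assay, with a stated time of 72 h; a higher number here means a weaker inhibitor, a lower number a stronger inhibitor. Compound 1 gives 1780 nM and compound 2 gives 3970 nM. For the measured compounds named here, compound 2 therefore stands at the highest of the two numbers, with compound 1 as its only neighbour; the step of a 2.2-fold higher number from compound 1 to compound 2 (0.35 log units; beyond the scatter) puts a methoxy in place of hydrogen on an aromatic carbon.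

Compound 3 `CN(C)CCn1cnnc1-c1cc(Oc2ccc(NC(=O)N/N=C/c3ccc(O)c(O)c3)cc2F)ccn1` has not yet been measured in this assay. Against compound 2 the change is 3,4-dihydroxyphenyl in place of 2,3,4-trimethoxyphenyl on a carbon with a double bond to nitrogen. Going by the values given here, only the single step from compound 1 to compound 2 bears on this change, and it does so loosely: it shows that adding one methoxy on that ring modestly raised the number, whereas here all three methoxy groups leave and two hydroxyls enter. On that basis the expected step of a 2.0-fold lower number from compound 2 to compound 3 (0.30 log units; within the scatter) is a modest lowering, with wide uncertainty. Compound 3 is therefore estimated at 2000 nM, with a plausible range from 600 nM to 7000 nM.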

Compound 3, half-maximal inhibitory concentration: 1890 nM
Estimate against measurement, compound 3: 1.1-fold (0.02 log units) above, within the range that was stated.
By their numbers in this assay, from the lowest: compounds 1 and 3 (each within the scatter of the next); then compound 2.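

In this assay the position on a carbon with a double bond to nitrogen does not depend on methoxy groups: the exchange of 2,3,4-trimethoxyphenyl for 3,4-dihydroxyphenyl, which takes the ring from 0 to 2 hydrogen-bond donors, gives a 2.1-fold lower number from compound 2 to compound 3 (0.32 log units; beyond the scatter) and so stays within a modest span. Against the 2,4-dimethoxyphenyl of compound 1, the same 3,4-dihydroxyphenyl gives a 1.1-fold higher number from compound 1 to compound 3 (0.03 log units; within the scatter) and so cannot be told apart from it, which leaves compound 2 as the only one of the three that stands off from the others. Nothing available here accounts for these steps.

The compounds shown leave open how this position would respond to a ring bearing a single hydroxyl, an amine or a carboxylic acid, and whether the hydroxyl groups of compound 3 contribute anything compared with an unsubstituted phenyl. They also leave open whether the same steps would hold on any core other than the one shared by all three compounds.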